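The source may report more compounds than this note shows. Statements on the series, on what has been measured and on what is new or still open speak of the compounds shown alone.

Compound 1 `CC(=O)N1CCC(c2ccc3c(c2)oc(=O)n3C(=O)NCCCCc2ccccc2)CC1`: < 1000 nM, a limit of the assay.
Compound 2 `CN1CCC(c2ccc3c(c2)oc(=O)n3C(=O)NCCCCc2ccc(F)cc2)CC1`: 22000 nM.
Compound 3 `CCCCCNC(=O)n1c(=O)oc2cc(-c3ccc(F)cc3)ccc21`: < 1000 nM, also a limit of the assay.

In a physicochemical assay for solubility, read by HPLC, in phosphate buffer, measured as kinetic solubility, with a stated time of 1 h, at pH 7.4, tested at 250 uM (on this read-out higher numbers stand for higher solubility and lower numbers for lower solubility), compound 1 gives no number, only a limit, and this is the limit of < 1000 nM in this assay, at which 2 of the 3 values shown sit. Among the measured compounds shown here, compound 2 is the one measured compound that gives a number in this assay, 22000 nM. Compound 4 `CCN1CCC(c2ccc3c(c2)oc(=O)n3C(=O)NCCCCc2ccccc2)CC1` differs from compound 1 in a single place: ethyl in place of acetyl on an amine nitrogen in a ring. For the measured compounds named here, no pair of measured compounds differs in one place, so no measured step guides the size of this change. Because compound 2 gives 22000 nM, compound 4 is expected to rise clearly beyond the scatter, an at least 15-fold higher number from compound 1 to compound 4 (1.17 log units; beyond the scatter). The estimate for compound 4 is 15000 nM, between 3000 nM and 50000 nM.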

Compound 4, solubility: 198000 nM
The estimate for compound 4 lay 13-fold (1.12 log units) below the measured number; measured number outside the range, above it.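

In this assay, ethyl in place of acetyl on an amine nitrogen in a ring goes with an at least 190-fold higher number from compound 1 to compound 4 (2.29 log units; beyond the scatter), the first single-place step read at this position. This one change, with the rest of the molecule untouched, is enough to move a compound from the limit of the assay to a measured number. Compound 1 gives only a limit, so the true size of the step stays unknown, and that limit is a shared one: the limit of < 1000 nM in this assay, at which 2 of the 4 values shown sit.

Still open, from the compounds shown here alone, is whether a longer chain such as propyl, or a carboxylic acid on this nitrogen, would give a similar number. Whether a free hydrogen on the nitrogen would do the same also remains unanswered.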